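This account rests on a few compounds, and the source may have more. Where it says the series, first, only, none or still open, it means among the compounds named here.

Compound 1 `CCN1CCc2c(sc(NC(=O)Nc3cccc(Cl)c3Cl)c2C(N)=O)C1` gives 17400 nM in a functional assay (strain AB) with Danio rerio as the target, read by microscopy, with a stated time of 1 h (a higher number here means that more compound is needed for the effect, a lower number that less compound is needed), a half-maximal effective concentration, so a fairly large amount of it is needed for the effect. This is the higher of the two actual numbers available. The other belongs to compound 2 `CC(C)(C)OC(=O)CCC[N+]1(C)CCc2c(sc(NC(=O)Nc3ccc(Cl)cc3)c2C(N)=O)C1`, which gives 250 nM, and the gap between the two lies well beyond the usual scatter of repeated measurements. Compound 3 `NC(=O)c1c(NC(=O)Nc2ccc(Cl)cc2)sc2c1CCCC2` has no number, only a limit of the assay, > 25000 nM.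

The next compound to be tested is compound 4 `CCN1CCc2c(sc(NC(=O)NCc3cccc(Cl)c3)c2C(N)=O)C1`. It keeps the core of compound 1 and changes one group, with 3-chlorobenzyl in place of 2,3-dichlorophenyl on an amide-type nitrogen. For the measured compounds named here, no two measured compounds differ in only one place, so the data show nothing directly about a swap of this kind. The starting point is therefore compound 1 at 17400 nM, and no step beyond the scatter is expected in this assay. The estimated change is a 1.2-fold lower number from compound 1 to compound 4 (0.06 log units; within the scatter), a small expected step with wide uncertainty. A result given only as a limit would be no surprise. For compound 4 the expected value is 15000 nM, with an estimated range from 4000 nM to 25000 nM.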

Compound 4, half-maximal effective concentration: > 25000 nM
Compound 4: no number, only a limit; the forecaster's own chance of this, stated with the estimate: 35%; at least 1.6-fold (0.22 log units) between middle value and limit.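

Compound 4 gives > 25000 nM in this assay, which is a limit of the assay and not a number. For the compounds shown here, this is the first comparison in which only one place changes, with 3-chlorobenzyl in place of 2,3-dichlorophenyl on an amide-type nitrogen, and the result is an at least 1.4-fold higher number from compound 1 to compound 4 (0.15 log units; that floor lies within the scatter). The swap brings no lower number, but it cannot be called a real loss either, since the smallest possible step is within the scatter and its true size stays hidden because of the ceiling of the read-out: the limit of > 25000 nM in this assay, at which 2 of the 4 values shown sit.

Since 3-chlorobenzyl differs from 2,3-dichlorophenyl in both its chlorine count and its carbon count, this single pair cannot show which of the two differences matters, if either does. Also open, from the compounds shown here alone, is what would happen with 2,3-dichlorobenzyl, with a longer chain ending in the same aromatic ring, or with a group carrying an amine or a carboxylic acid on this amide-type nitrogen.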